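Chloro to trifluoromethyl on a second core

The source may hold more compounds than are shown below. What is called first, only, known or untested is meant among the compounds shown, and "the series" means these compounds.

Compound 1 `COc1ccc(-c2nn(-c3ccccc3)cc2C(=O)/C=C\Nc2ccc(Cl)cc2)cc1` and compound 2 `COc1ccc(-c2nn(-c3ccccc3)cc2C(=O)/C=C\Nc2ccc(C(F)(F)F)cc2)cc1` share a core and differ by trifluoromethyl in place of chloro on an aromatic carbon. In a functional assay on HT-29 cells (Homo sapiens) for antiproliferative activity, read by MTT assay, with a stated time of 48 h (a higher number here means a weaker inhibitor, a lower number a stronger inhibitor), compound 1 gives 4760 nM, and compound 2 gives 9870 nM, so that a 2.1-fold higher number from compound 1 to compound 2 (0.32 log units; beyond the scatter). Compound 3 `COc1cc(-c2nn(-c3ccccc3)cc2C(=O)/C=C\Nc2ccc(Cl)cc2)cc(OC)c1OC` carries a different core; how the two cores differ is not broken down here. In this assay compound 3 gives 7680 nM. Compound 4 `COc1cc(-c2nn(-c3ccccc3)cc2C(=O)/C=C\Nc2ccc(C(F)(F)F)cc2)cc(OC)c1OC` is not yet measured and differs from compound 3 by trifluoromethyl in place of chloro on an aromatic carbon, the same change as that from compound 1 to compound 2, made at the same place. Because the earlier step was a 2.1-fold higher number from compound 1 to compound 2 (0.32 log units; beyond the scatter), a step of similar size is expected for compound 4, namely a 2.0-fold higher number from compound 3 to compound 4 (0.29 log units; within the scatter) in this assay. Compound 4 is therefore estimated at 15000 nM, with a likely range from 6500 nM to 35000 nM.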

Compound 4, half-maximal inhibitory concentration: > 50000 nM
Compound 4: no number, only a limit; the forecaster's own chance of this, stated with the estimate: 10%; at least 3.3-fold (0.52 log units) between middle value and limit.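

In this assay compound 4 gives > 50000 nM, which is a limit of the assay and not a number. On the core of compound 3, the change gives an at least 6.5-fold higher number from compound 3 to compound 4 (0.81 log units; beyond the scatter), while 3,4,5-trimethoxyphenyl in place of 4-methoxyphenyl, with trifluoromethyl kept, gives an at least 5.0-fold higher number from compound 2 to compound 4 (0.70 log units; beyond the scatter). The change thus moves the number the same way on both cores but does not carry over at one size, although the full size of the second step stays unknown and two cores say nothing about any others: the same change on two cores in this assay, a 2.1-fold higher number (0.32 log units; beyond the scatter) from compound 1 to compound 2 and an at least 6.5-fold higher number (0.81 log units; beyond the scatter) from compound 3 to compound 4, at least 3.1-fold (0.49 log units) apart, beyond the scatter of two such steps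

The compounds shown leave open how a nitrile or a fluoro group in place of chloro would read on these two cores. They also leave open whether a core with an amine or a carboxylic acid would follow either step.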